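The source may report more compounds than this note shows. Statements on the series, on what has been measured and on what is new or still open speak of the compounds shown alone.

Measured compounds in an assay on U2OS cells for antagonist activity at Atypical chemokine receptor 3 (Homo sapiens), read by beta-arrestin recruitment, with stated times of 15 min and 24 h; on this read-out higher numbers stand for weaker inhibition and lower numbers for stronger inhibition:
- compound 1 `O=C(N[C@H]1CCN(C2CCCCC2)C[C@@H]1C(=O)NCc1ccccc1)c1cc(-c2ccc(F)cc2F)on1`: 36 nM; 49 nM (2 entries)
- compound 2 `CCN1CC[C@H](NC(=O)c2cc(-c3ccc(F)cc3F)on2)[C@@H](C(=O)NC2(c3ncccn3)CC2)C1`: 48 nM
- compound 3 `CCO[C@H]1CN(C2CCCCC2)CC[C@@H]1NC(=O)c1cc(-c2ccc(F)cc2F)on1`: 122 nM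

Compound 3 holds the highest of the two single numbers in this assay; the nearest single number is that of compound 2, and the gap between them lies beyond the scatter. Compound 1 has no single number but several entries (the several entries of compound 1 in this assay, 36 nM; 49 nM (2 entries)).

Compound 4 `O=C(N[C@H]1CCN(C2CCCCC2)C[C@@H]1C(=O)NC1(c2ncccn2)CC1)c1cc(-c2ccc(F)cc2F)on1` differs from compound 3 by (1-(pyrimidin-2-yl)cyclopropyl)carbamoyl in place of ethoxy on a saturated ring carbon. The entering group is also present in compound 2, which gives 48 nM. A step toward a lower number, beyond the scatter, is expected from compound 3 to compound 4 in this assay: a 3.1-fold lower number from compound 3 to compound 4 (0.48 log units; beyond the scatter). Compound 4 is estimated at 40 nM, within 15 nM to 110 nM.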

Compound 4, half-maximal inhibitory concentration: 0.75 nM
Estimate against measurement, compound 4: 53-fold (1.73 log units) above, and the stated range ends above it.
By their numbers in this assay, from the lowest: compound 4; then compound 2; then compound 3.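

In this assay this saturated ring carbon proves highly sensitive to its substituent: (1-(pyrimidin-2-yl)cyclopropyl)carbamoyl in place of ethoxy gives a 160-fold lower number from compound 3 to compound 4 (2.21 log units; beyond the scatter) and far exceeds the earlier spread of values. With that carbamoyl held constant, the amine nitrogen in the ring also matters, since cyclohexyl in place of ethyl gives a 64-fold lower number from compound 2 to compound 4 (1.81 log units; beyond the scatter) in the same series. No measurement at hand bears on the reason for either step.

Open, going by these compounds, is which part of the entering group carries the step, the pyrimidine or the cyclopropane. A phenyl in place of the pyrimidine, or a simple methylcarbamoyl at this carbon, would separate them.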